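A few compounds are considered here, and "the series" means these few. Any claim that something is new, unique, unknown or untested is made for them only; others in the source may bear on it.

In an ADME assay on MT4 cells (Homo sapiens) for cytotoxicity, read by MTT assay, with a stated time of 5 days (on this read-out higher numbers stand for lower toxicity in this test and lower numbers for higher toxicity in this test), three compounds sharing one core have been measured: compound 1 (`O=c1[nH]c2ccc(Cl)cc2n1S(=O)(=O)Cc1ccccc1Cl`) gives 52000 nM, compound 2 (`O=c1[nH]c2ccc(Cl)cc2n1S(=O)(=O)Cc1ccc(Cl)cc1`) gives 77000 nM, and compound 3 (`Cc1ccc(CS(=O)(=O)n2c(=O)[nH]c3ccc(Cl)cc32)cc1`) gives 93000 nM. Compound 3 lies within the scatter of both other compounds, so the numbers do not separate the three. Compound 4 (`O=c1[nH]c2ccc(Cl)cc2n1S(=O)(=O)CCc1ccccc1`) has the same atoms as compound 3, joined differently: benzyl in place of 4-methylphenyl on a saturated chain carbon bound to a sulfonyl sulfur. Among the measured compounds shown here, three measured steps bear on this change, all made in the group at that end of the molecule: a 1.5-fold higher number from compound 1 to compound 2 (0.17 log units; within the scatter), a 1.8-fold higher number from compound 1 to compound 3 (0.25 log units; within the scatter) and a 1.2-fold higher number from compound 2 to compound 3 (0.08 log units; within the scatter). Each is small and within the scatter, but none makes this exact exchange, so the evidence is indirect. On that basis, no step beyond the scatter is expected in this assay, and no direction can be favoured. The expected change is a 1.2-fold lower number from compound 3 to compound 4 (0.09 log units; within the scatter). For compound 4 the estimated value is 75000 nM, with an expected range from 38000 nM to 140000 nM.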

Compound 4, half-maximal cytotoxic concentration: 30000 nM
The estimate for compound 4 lay 2.5-fold (0.40 log units) above the measured number; measured number outside the range, below it.
By their numbers in this assay, from the lowest: compounds 4, 1, 2 and 3 (each within the scatter of the next, the first and the last beyond it).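

In this assay, the place on a saturated chain carbon bound to a sulfonyl sulfur now shows steps beyond the scatter, which none of the earlier exchanges there had done: benzyl in place of 4-methylphenyl gives a 3.1-fold lower number from compound 3 to compound 4 (0.49 log units; beyond the scatter) even though the two compounds have the same atoms, joined differently. Benzyl in place of 4-chlorophenyl points the same way with a 2.6-fold lower number from compound 2 to compound 4 (0.41 log units; beyond the scatter) and lies beyond the scatter as well. Benzyl in place of 2-chlorophenyl does not go with this pattern, since a 1.7-fold lower number from compound 1 to compound 4 (0.24 log units; within the scatter) stays within the scatter, and nothing available accounts for any of these steps.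

The compounds shown leave open how a longer chain at this place would read in this assay. They also leave open how an amine or a carboxylic acid on the aromatic ring of compound 4 would read there.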